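Aryl substitution at the imide nitrogen of the shared core

The source may report more compounds than this note shows. Statements on the series, on what has been measured and on what is new or still open speak of the compounds shown alone.

Measured compounds:
- compound 1, `CCCc1ccc(N2C(=O)NC3(CSC4=C3C(=O)c3ncccc3C4=O)C2=O)cc1`: 1 nM
- compound 2, `O=C1NC(=O)C2(CSC3=C2C(=O)c2ncccc2C3=O)N1`: 190 nM; 180 nM; 190 nM (3 entries)
- compound 3, `O=C1C2=C(C(=O)c3ncccc31)C1(CS2)NC(=O)N(c2ccc(Cl)cc2)C1=O`: 2 nM

Among the compounds with values here, in a functional assay on HT-29 cells (Homo sapiens) for antiproliferative activity, read by MTT assay, with a stated time of 96 h (on this read-out lower numbers stand for stronger inhibition and higher numbers for weaker inhibition), compound 3 gives 2 nM and stands next to compound 1, which gives 1 nM; the only single-point step, a 2.0-fold higher number from compound 1 to compound 3 (0.30 log units; within the scatter), lies within the scatter, so the two aryl-bearing compounds are not distinguished. Compound 2, with the several entries of compound 2 in this assay, 190 nM; 180 nM; 190 nM (3 entries), sits far from both, the aryl group on the shared core thus going with the low numbers.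

Compound 4, `O=C1C2=C(C(=O)c3ncccc31)C1(CS2)NC(=O)N(c2ccc([N+](=O)[O-])cc2)C1=O`, is to be measured in this assay. It differs from compound 3 by nitro in place of chloro on an aromatic carbon. Within the data shown here, the one step measured on the aryl ring, a 2.0-fold higher number from compound 1 to compound 3 (0.30 log units; within the scatter), was within the scatter, and no other step bears on a change at this position. On that basis a step no larger than the scatter is expected, with no direction favoured; the estimated step of a 1.5-fold higher number from compound 3 to compound 4 (0.18 log units; within the scatter) is small.

Compound 4 is therefore expected to give 3 nM in this assay, within a range of 1 nM to 12 nM.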

Compound 4, half-maximal inhibitory concentration: 250 nM
Compound 4: the middle estimate sits 83-fold (1.92 log units) below what was measured; measured number above the stated range.
By their numbers in this assay, from the lowest: compounds 1 and 3 (each within the scatter of the next); then compound 4.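

The aryl ring does not keep the low numbers whatever it carries: in this assay the step to 4-nitrophenyl is large, with a 130-fold higher number from compound 3 to compound 4 (2.10 log units; beyond the scatter) and a 250-fold higher number from compound 1 to compound 4 (2.40 log units; beyond the scatter) both set against chloro and propyl, which were not distinguished from each other. The group at this place on the ring therefore decides the outcome, so the earlier link between the aryl group and low numbers holds for compound 1 and compound 3 but not for compound 4. Compound 4, at 250 nM in this assay, stands in the same region as the core without an aryl group: the several entries of compound 2 in this assay, 190 nM; 180 nM; 190 nM (3 entries).

On these data alone, whether nitro stands alone or other groups at this place also give high numbers remains open. An amine, a carboxylic acid or a longer chain on the ring would help to settle this.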